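Replacing the Methoxy Group of Compound 1

A few compounds are considered here, and "the series" means these few. Any claim that something is new, unique, unknown or untested is made for them only; others in the source may bear on it.

For the measured compounds named here, in a functional assay on NCI-H460 cells (Homo sapiens) for cytotoxicity, read by MTT assay, with a stated time of 68 h (on this read-out higher numbers stand for weaker inhibition and lower numbers for stronger inhibition), compound 1 (`COc1cccc(-c2cccc(NC(=O)C(Cl)Cl)c2)c1`) gives 33800 nM, the only true number available so far. Compound 2 (`COc1cccc(-c2cc(NC(=O)C(Cl)Cl)cc(-c3cccc(OC)c3)c2)c1`) reads > 30000 nM, which is a limit of the assay and not a number. The two therefore cannot be ranked against each other with any precision.

Compound 3 (`O=C(Nc1cccc(-c2cccc(NC(=O)C(Cl)Cl)c2)c1)C(Cl)Cl`) departs from compound 1 at a single place, with ((dichloromethyl)carbonyl)amino in place of methoxy on an aromatic carbon.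

Going by the values given here, the only measured step nearby is a step that the limit leaves unreadable from compound 1 to compound 2. It has no readable size, and it adds a 3-methoxyphenyl group instead of replacing methoxy, so it offers no guide to direction or size for the new change. Among the compounds with values here, with no measured step to lean on, the expectation starts from compound 1 at 33800 nM, and no shift beyond the usual scatter is expected in this assay. The estimated change is a 1.4-fold lower number from compound 1 to compound 3 (0.13 log units; within the scatter). For compound 3, the expected value is 25000 nM, within an estimated range of 8000 nM to 70000 nM.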

Compound 3, half-maximal inhibitory concentration: > 50000 nM
Compound 3 was reported as a limit; the forecaster's own chance of this, stated with the estimate: 35%; middle value at least 2.0-fold (0.30 log units) from the limit.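

Putting ((dichloromethyl)carbonyl)amino in place of methoxy on this aromatic carbon gives an at least 1.4-fold higher number from compound 1 to compound 3 (0.17 log units; that floor lies within the scatter), so this swap brings no stronger inhibition in this assay, although the floor of the step does not show a real loss either. For the compounds shown here, the true size of the step stays unknown because the value of compound 3 is a limit of the assay and not a number: the limit of > 50000 nM in this assay, at which 1 of the 3 values shown sits. The step from compound 1 to compound 2 cannot be read and involved an added 3-methoxyphenyl group, so this is the first sign of direction for replacing the methoxy group itself, and it points only toward equal or weaker inhibition.

From the compounds shown here alone, what an amine, a hydroxyl group or a carboxylic acid would do in place of methoxy on this carbon remains open. Also open, going by these compounds, is whether any group at this position can move the number for the shared core clearly lower than that of compound 1, which gives 33800 nM, since neither of the other two compounds gives a true number to compare with it.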